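The compounds below may be only part of what the source reports. "The series", "measured", "known", "first", "only" and "open" are said of these compounds alone.

Compound 2, `COc1cc(N)c(Cl)cc1NC(=O)C1CCN(Cc2ccc(F)cc2)CC1`, carries a 4-fluorophenyl on a saturated chain carbon bound to an amine nitrogen in a ring. For the measured compounds named here, in a functional assay on the whole organism for antagonist activity, with Mus musculus as the target (a higher number here means that more compound is needed for the effect, a lower number that less compound is needed), compound 2 gives 0.6 mg/kg, the only real number among the three values shown. Compound 1, `CCCCN1CCC(C(=O)Nc2cc(Cl)c(N)cc2OC)CC1`, carries propyl in that place. In this assay compound 1 reaches only a limit, > 10 mg/kg. Compound 3, `COc1cc(N)c(Cl)cc1NC(=O)C1CCN(Cc2ccc([N+](=O)[O-])cc2)CC1`, carries 4-nitrophenyl there. In this assay compound 3 also gives a limit, > 4 mg/kg. The step of an at least 16-fold lower number from compound 1 to compound 2 (1.22 log units; beyond the scatter) shows that 4-fluorophenyl in place of propyl brought a large drop in the dose needed, while an at least 6.6-fold higher number from compound 2 to compound 3 (0.82 log units; beyond the scatter) shows that nitro in place of fluoro raised it again.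

Compound 4, `CCCCCN1CCC(C(=O)Nc2cc(Cl)c(N)cc2OC)CC1`, differs from compound 2 by butyl in place of 4-fluorophenyl on a saturated chain carbon bound to an amine nitrogen in a ring. This largely undoes the change that separated compound 1 from compound 2, since a saturated chain again replaces the ring. That earlier step bears directly on the present one; because an at least 16-fold lower number from compound 1 to compound 2 (1.22 log units; beyond the scatter) was large, compound 4 is expected to need far more compound than compound 2. The expected step is a 17-fold higher number from compound 2 to compound 4 (1.22 log units; beyond the scatter). Compound 4 is therefore estimated at 10 mg/kg, with a range from 3 mg/kg to 30 mg/kg, and the result may well come back as a limit.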

Compound 4, dose for half-maximal effect: > 10 mg/kg
Compound 4 gave a limit, no number; the forecaster's own chance of this, stated with the estimate: 60%; the middle value sits exactly at the limit.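

The step of an at least 16-fold higher number from compound 2 to compound 4 (1.22 log units; beyond the scatter) shows that the 4-fluorobenzyl group of compound 2 keeps its large lead over a second saturated chain, so that lead does not rest on a comparison with a single chain length. In this assay compound 4 gives > 10 mg/kg, which is a limit and not a number, so the effect of making the chain longer cannot be judged at this end of the scale: the limit of > 10 mg/kg in this assay, at which 2 of the 4 values shown sit. The steps from compound 1 to compound 4 and from compound 3 to compound 4 cannot be read, and neither the added methyl nor the exchange of the 4-nitrophenyl for butyl gets a size.

Still open, on these data alone, is whether any saturated chain at this place, such as a much longer hexyl or octyl chain, could come near compound 2, which gives 0.6 mg/kg. Also open, as far as these compounds go, is how a plain unsubstituted benzyl group or a 4-methoxybenzyl group would stand, which would separate the part played by the ring from the part played by the fluorine on it.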